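Working notes: removing one methyl from compound 3

The compounds below may be only part of what the source reports. "The series", "measured", "known", "first", "only" and "open" are said of these compounds alone.

Measured so far in a functional assay on SF-295 cells (Homo sapiens); on this read-out higher numbers stand for weaker inhibition of growth and lower numbers for stronger inhibition of growth
compound 1 `Cc1cc(C)c2c(O)cc(-c3ccc(Cl)cc3)nc2n1` gives 16200 nM
compound 2 `COc1ccc(-c2cc(O)c3c(C)cc(C)nc3n2)cc1` gives 42700 nM
compound 3 `COc1cccc(-c2cc(O)c3c(C)cc(C)nc3n2)c1` gives 417 nM

Compound 3 has the lowest number of the three and lies well clear of both others. Compound 4 `COc1cccc(-c2cc(O)c3c(C)ccnc3n2)c1` is reached from compound 3 by one change hydrogen in place of methyl on an aromatic carbon with hydrogen in place of methyl on an aromatic carbon, next to the ring nitrogen.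

Within the data shown here, the only measured step between two compounds differing in one place is a 2.6-fold higher number from compound 1 to compound 2 (0.42 log units; beyond the scatter) and it is modest. That step is methoxy in place of chloro, at another place in the molecule, so it gives little guidance here. Among the measured compounds shown here, no measured step removes a methyl from the shared core. Compound 2 at 42700 nM and compound 3 at 417 nM both carry methoxy yet lie far apart, so large moves do occur in this small set. With compound 3 at 417 nM at the low end of the set, a moderate rise is more likely than a further drop. The expected move is a 1.9-fold higher number from compound 3 to compound 4 (0.28 log units; within the scatter) and its size remains poorly fixed. For compound 4 the estimated value in this assay is 800 nM with an expected range of 150 nM to 5000 nM in these notes.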

Compound 4, concentration for 50% growth inhibition: 28.8 nM
Estimate against measurement, compound 4: 28-fold (1.44 log units) above; the measured number lies below the stated range.
By their numbers in this assay, from the lowest: compound 4; then compound 3; then compound 1; then compound 2.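

In this assay, taking away the methyl next to the ring nitrogen gives a 14-fold lower number from compound 3 to compound 4 (1.16 log units; beyond the scatter), the first measured step on the shared core, and this methyl is shown to be dispensable for growth inhibition in the one pair available, with hydrogen on this aromatic carbon giving the lower number. The position therefore responds strongly to a change of a single heavy atom, and this step is clearly larger than the only other one, a 2.6-fold higher number from compound 1 to compound 2 (0.42 log units; beyond the scatter), which exchanges chloro for methoxy at another place in the molecule. Nothing shown here accounts for the size of the step on the core.

The compounds shown leave open whether other groups at this position, such as ethyl, an amine or a methoxy group, keep or lose the low number, and whether the remaining methyl on the same ring can also give way to hydrogen. They also leave open whether the same removal of the methyl lowers the number on the backgrounds of compound 1 and compound 2, as the effect is read on a single pair.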